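Adding a Methoxy Group to the Phenyl of Compound 1

A few compounds are considered here, and "the series" means these few. Any claim that something is new, unique, unknown or untested is made for them only; others in the source may bear on it.

In a functional assay on U-87MG ATCC cells for antiproliferative activity against U-87 MG (Homo sapiens), read by MTT assay, with a stated time of 48 h, tested at 50 uM (a lower number here means a stronger effect, a higher number a weaker effect of the compound at the concentration tested), compound 1 `COc1ccc(-c2nc(C)c(C(=O)CSc3nc(N)c(C#N)c(-c4ccccc4)n3)s2)cc1` gives 16.5%, the lowest of the three measured numbers. Compound 2 `COc1ccc(-c2nc(C)c(C(=O)CSc3nc(-c4ccc(OC)cc4)c(C#N)c(=O)[nH]3)s2)cc1` gives 32.6% and compound 3 `COc1ccc(-c2nc(C)c(C(=O)CSc3nc(-c4ccc(OC)c(OC)c4)c(C#N)c(=O)[nH]3)s2)cc1` gives 22.2%. The difference between the core of compound 1 and the core of compound 2 is not broken down here. From compound 2 to compound 3 the change is methoxy in place of hydrogen on an aromatic carbon, and the step of a number 10.4 percentage points lower from compound 2 to compound 3 (beyond the scatter). Compound 4 `COc1ccc(-c2nc(C)c(C(=O)CSc3nc(N)c(C#N)c(-c4ccc(OC)cc4)n3)s2)cc1` has not been measured; it differs from compound 1 by methoxy in place of hydrogen on an aromatic carbon, the same kind of change, though here the place is para to a large group rather than ortho to a methoxy group and meta to a large group. Because the step of a number 10.4 percentage points lower from compound 2 to compound 3 (beyond the scatter) went lower, compound 4 is expected to move a number 6.5 percentage points lower from compound 1 to compound 4 (within the scatter). The estimate for compound 4 is 10%, expected between 3% and 20%.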

Compound 4, a percentage reported as activity, at one concentration (the size of the read-out at that concentration, not a potency): 13%
Beside the measured number, compound 4's estimate is 3 percentage points below it, and the stated range covers the measured number.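

In this assay, phenyl to 4-methoxyphenyl on the core of compound 1 gives a number 3.5 percentage points lower from compound 1 to compound 4 (within the scatter). Set beside the earlier step, the size of this change does not differ measurably between the two cores: the same change on two cores in this assay, a number 10.4 percentage points lower (beyond the scatter) from compound 2 to compound 3 and a number 3.5 percentage points lower (within the scatter) from compound 1 to compound 4, 6.9 percentage points apart, within the scatter of two such steps This does not show a real effect of the methoxy group on the core of compound 1, where the step stays within the scatter, and two pairs of compounds set no rule for the series.

The compounds shown leave open how a hydroxyl, an amine or a carboxylic acid in place of the methoxy group would read in this assay. As far as these compounds go, it is also open whether a longer chain such as ethoxy would read differently on either core.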